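The compounds below may be only part of what the source reports. "The series", "measured", "known", "first", "only" and "open" are said of these compounds alone.

Measured compounds:

compound 1, `CCN(CC)S(=O)(=O)c1ccc(S(=O)(=O)N2CCC[C@@H](C(=O)N3CCN(c4nc(C(F)(F)F)no4)CC3)C2)cc1`: 60 nM
compound 2, `CCN(CC)S(=O)(=O)c1ccc(S(=O)(=O)N2CCC[C@@H](C(=O)N3CCN(c4nc(C(C)C)no4)CC3)C2)cc1`: 30 nM

In a functional assay on MIA PaCa-2 cells (Homo sapiens) for inhibition, read by MTT assay, with a stated time of 3 days (a lower number here means a stronger inhibitor, a higher number a weaker inhibitor), compound 1 gives 60 nM and compound 2 gives 30 nM. Compound 2 shows the lower of the two numbers, but the gap to compound 1 is within the scatter, so the two compounds cannot be set apart on this evidence. Within the data shown here, the only measured step, a 2.0-fold lower number from compound 1 to compound 2 (0.30 log units; within the scatter), exchanges one substituent on the oxadiazole for another and leaves the ring itself in place.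

Compound 3, `CCN(CC)S(=O)(=O)c1ccc(S(=O)(=O)N2CCC[C@@H](C(=O)N3CCN(C(=O)OC(C)(C)C)CC3)C2)cc1`, departs from compound 2 in a different way: tert-butoxycarbonyl in place of 3-isopropyl-1,2,4-oxadiazol-5-yl on an amine nitrogen in a ring. Among the measured compounds shown here, no measured step in this assay removes the oxadiazole ring or introduces a carbamate, so the step from compound 1 to compound 2 bears on it only loosely. For the measured compounds named here, with no direct precedent, the estimate for compound 3 is that the number rises by a 6.7-fold higher number from compound 2 to compound 3 (0.82 log units; beyond the scatter), a step expected to be beyond the scatter but carrying wide uncertainty. Compound 3 is accordingly estimated at 200 nM in this assay, within a range of 40 nM to 1000 nM.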

Compound 3, half-maximal inhibitory concentration: 10 nM
Estimate against measurement, compound 3: 20-fold (1.30 log units) above; the measured number lies below the stated range.
By their numbers in this assay, from the lowest: compound 3; then compounds 2 and 1 (each within the scatter of the next).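

The change at this amine nitrogen in a ring reaches further than the earlier comparison did: compounds 1 and 2 varied only the substituent on the oxadiazole and stayed within the scatter, whereas replacing the whole ring gives a 3.0-fold lower number from compound 2 to compound 3 (0.48 log units; beyond the scatter) in this assay. The same replacement starting from the trifluoromethyl analogue gives a 6.0-fold lower number from compound 1 to compound 3 (0.78 log units; beyond the scatter), so with both steps modest but beyond the scatter, compound 3, which carries tert-butoxycarbonyl, is the most potent of the three, and a five-membered aromatic ring at this position is not required for a low number here. Nothing available explains why the open carbamate gives the lower number.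

The compounds shown do not separate the contributions of the tert-butyl part, the carbonyl and the carbamate oxygen, which a plain acetyl group, a urea or the free ring amine on the same nitrogen could begin to do. They also leave open whether other aromatic rings at this nitrogen, such as a pyridine or a differently arranged oxadiazole, would give numbers closer to compound 3 or to compound 2.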